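The source may hold more compounds than are shown below. What is called first, only, known or untested is meant among the compounds shown, and "the series" means these compounds.

Measured so far in a functional assay on BGC-823 cells (Homo sapiens) for cytotoxicity, read by MTT assay; on this read-out higher numbers stand for weaker inhibition and lower numbers for stronger inhibition:
- compound 1 `COc1cc(/C=C/C(=O)c2sc(Nc3cccc(Cl)c3)nc2C)cc(OC)c1OC` gives 11600 nM
- compound 2 `COc1cc(/C=C/C(=O)c2sc(Nc3ccc(F)c(Cl)c3)nc2C)cc(OC)c1OC` gives 9700 nM
- compound 3 `COc1cccc(/C=C/C(=O)c2sc(Nc3ccccc3C)nc2C)c1` gives > 25000 nM; this is a limit of this assay, not a number

Going by the values given here, compound 2 stands at the lowest of the two numbers in hand; compound 1 is its nearest neighbour, and the single measured step, a 1.2-fold lower number from compound 1 to compound 2 (0.08 log units; within the scatter), falls within the scatter, so the two are not separated. The reading for compound 3 sits at the limit of > 25000 nM in this assay, at which 1 of the 3 values shown sits, and tells only that much.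

Compound 4 `COc1cc(/C=C/C(=O)c2sc(Nc3ccccc3C)nc2C)cc(OC)c1OC` is not yet measured. It differs from compound 2 in one place: 2-methylphenyl in place of 3-chloro-4-fluorophenyl on a nitrogen on an aromatic ring. Among the compounds with values here, no measured step covers this change. Compound 3 carries the same 2-methylphenyl group on the nitrogen but differs from compound 4 in a second place as well, so its limit speaks to compound 4 only loosely. Within the data shown here, the one measured step on the series is small, yet the limit seen with the 2-methylphenyl group argues for a weaker outcome. The expected step of a 1.9-fold higher number from compound 2 to compound 4 (0.27 log units; within the scatter) is therefore towards a higher number, with a fair chance that only a limit is returned. Compound 4 is estimated at 18000 nM, within 8000 nM to 40000 nM.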

Compound 4, half-maximal inhibitory concentration: 5400 nM
Estimate against measurement, compound 4: 3.3-fold (0.52 log units) above; measured number below the stated range.
By their numbers in this assay, from the lowest: compounds 4, 2 and 1 (each within the scatter of the next, the first and the last beyond it). At a limit, above all of these: compound 3.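

The step of a 1.8-fold lower number from compound 2 to compound 4 (0.25 log units; within the scatter) lies within the scatter, so 3-chloro-4-fluorophenyl and 2-methylphenyl on this nitrogen are not separated in this assay. Set against 3-chlorophenyl, the same change gives the first step in the series beyond the scatter, though only a modest one: a 2.1-fold lower number from compound 1 to compound 4 (0.33 log units; beyond the scatter). Compound 3, which carries the same 2-methylphenyl group on the nitrogen, remains at a limit and not a number, so this group does not by itself bring a limit in the series: the limit of > 25000 nM in this assay, at which 1 of the 4 values shown sits.

Only substituted phenyl groups stand on this nitrogen in the compounds shown, so it remains open whether an unsubstituted phenyl, a cyclohexyl ring, a longer chain or a phenyl bearing a carboxylic acid would keep a number in this range. Going by these compounds alone, the methoxy groups on the other aromatic ring also remain unresolved, since the only pair that speaks to them, compound 3 and compound 4, gives one number and one limit, which sets no size for that change.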